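Adding an Acetyl Group to the Amine Nitrogen of Compound 3

The source may hold more compounds than are shown below. What is called first, only, known or untested is meant among the compounds shown, and "the series" means these compounds.

The measured compounds:
Compound 1, `NN1C(=O)/C(=C/c2ccc(Cl)cc2)SC1=S`, reported as "not active" (no number reported) in an assay for inhibition of LL-diaminopimelate aminotransferase, chloroplastic (Arabidopsis thaliana) (on this read-out higher numbers stand for weaker inhibition and lower numbers for stronger inhibition), with no number given.
Compound 2, `CCN1C(=O)/C(=C/c2ccnc3ccccc23)SC1=S`, with 190000 nM in this assay.
Compound 3, `COc1ccc(/C=C2\SC(=S)N(N)C2=O)cc1`, with 155000 nM in this assay.

Compound 3 gives the lower of the two reported numbers, but its gap to compound 2 lies within the usual scatter, so the two cannot be placed in any order. Compound 1 is without a number, being reported only as not active.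

Compound 4, `COc1ccc(/C=C2\SC(=S)N(NC(C)=O)C2=O)cc1`, differs from compound 3 in one place: acetyl in place of hydrogen on an amine nitrogen. For the measured compounds named here, no measured pair shows this change, so its effect can only be guessed. Since all three measured compounds sit at the weak end of this assay, and a small addition of this kind gives no reason to expect a large move, the expected step from compound 3 to compound 4 is a 1.3-fold higher number from compound 3 to compound 4 (0.11 log units; within the scatter), not beyond the scatter. Compound 4 is therefore estimated at 200000 nM, with a likely range from 80000 nM to 500000 nM.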

Compound 4, half-maximal inhibitory concentration: > 200000 nM
Compound 4 ended at the assay's limit; the forecaster's own chance of this, stated with the estimate: 35%; the middle value sits exactly at the limit.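

In this assay compound 4 gives > 200000 nM, which is a limit of the assay and not a number. From the compounds shown here alone, replacing hydrogen with acetyl on the amine nitrogen, the change from amino to acetamido, gives an at least 1.2-fold higher number from compound 3 to compound 4 (0.11 log units; that floor lies within the scatter), so only a floor for this step can be read and its true size stays unknown. For the compounds shown here, this is the first view of a change at this position, and it shows no gain in inhibition from acetyl there, though the reading stops at the end of the assay's range: the limit of > 200000 nM in this assay, at which 1 of the 4 values shown sits.

Still open, going by these compounds, is whether any other group on this amine nitrogen, such as a methyl group or a benzoyl group, would give a number that can be read. Also open, on these data alone, is whether such a group would move the number lower or higher.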